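A few compounds are considered here, and "the series" means these few. Any claim that something is new, unique, unknown or untested is made for them only; others in the source may bear on it.

Measured compounds:
- compound 1 `CN(C)CCCNc1nc(-c2ccc(NC(=O)Nc3ccccc3F)cc2)nc2ccsc12`: 530 nM
- compound 2 `CN(C)CCCNc1nc(-c2ccc(NC(=O)Nc3ccccc3Cl)cc2)nc2c(Cl)c(Cl)sc12`: 490 nM
- compound 3 `CN(C)CCNc1nc(-c2ccc(NC(=O)Nc3ccccc3)cc2)nc2ccsc12`: 640 nM

In a functional assay on NCI-H460 cells (Homo sapiens) for cytotoxicity, read by MTT assay, with a stated time of 72 h (on this read-out lower numbers stand for stronger inhibition and higher numbers for weaker inhibition), compound 3 gives 640 nM, the highest of the three numbers shown, but its gaps to the others lie within the scatter: compound 1 gives 530 nM and compound 2 gives 490 nM, so the three compounds cannot be told apart on this read-out.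

Compound 4 `CN(C)CCNc1nc(-c2ccc(NC(=O)Nc3ccccc3Cl)cc2)nc2ccsc12` has not yet been measured in this assay. It differs from compound 3 in one place: chloro in place of hydrogen on an aromatic carbon. Among the compounds with values here, no step between two measured compounds isolates this change, since compound 1 and compound 2 each differ from compound 3 in more than one place. What the three values do show is that a fluoro on that ring in compound 1, a chloro on that ring in compound 2 and no substituent there in compound 3 all land in the same narrow band.

On that basis compound 4 is expected to stay within the scatter of compound 3, with a step from compound 3 to compound 4 of a 1.2-fold lower number from compound 3 to compound 4 (0.09 log units; within the scatter) that is not meaningful in either direction. The estimate for compound 4 in this assay is 520 nM, within a range of 250 nM to 1100 nM.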

Compound 4, half-maximal inhibitory concentration: 230 nM
The estimate for compound 4 lay 2.3-fold (0.35 log units) above the measured number; measured number outside the range, below it.
By their numbers in this assay, from the lowest: compound 4; then compounds 2, 1 and 3 (each within the scatter of the next).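

In this assay, within the data shown here, the change from phenyl to 2-chlorophenyl gives a 2.8-fold lower number from compound 3 to compound 4 (0.44 log units; beyond the scatter) and is the only step here that isolates a single change; although modest, it lies beyond the scatter. Compounds 1, 2 and 3 differ from one another in more than one place and sit within the scatter of each other, so they gave no sign that this position could register a change, whereas this pair shows that chloro in place of hydrogen on this aromatic carbon, ortho to a large group, does shift the number on the core shared by compound 3 and compound 4. No measurement at hand bears on why this single chlorine atom has this effect.

The compounds shown leave open whether a methyl, a methoxy or a fluoro at this same carbon would give a step of similar size, and whether chloro at another carbon of that ring would do the same. They also leave open whether the step carries over to the longer amine chain of compound 1 or to the core of compound 2, which bears two further chloro groups.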